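The source may hold more compounds than are shown below. What is called first, only, known or untested is meant among the compounds shown, and "the series" means these compounds.

Measured so far:
compound 1, `Cn1c(=O)c(C(=O)NCCN)c(O)c2ccccc21`: 11.5%
compound 2, `Cn1c(=O)c(C(=O)NCCCCCCN)c(O)c2ccccc21`: 8.3%

In a functional assay, with a stated time of 60 min, tested at 0.1 mM (on this read-out lower numbers stand for a weaker effect and higher numbers for a stronger effect at the one concentration tested), compound 1 gives 11.5% and compound 2 gives 8.3%. Compound 2 carries the smaller of the two numbers, yet the step of a number 3.2 percentage points lower from compound 1 to compound 2 (within the scatter) lies within the scatter, so the two are not told apart. Compound 3, `Cn1c(=O)c(C(=O)Nc2ccccc2N)c(O)c2ccccc21`, differs from compound 2 by 2-aminophenyl in place of 6-aminohexyl on an amide-type nitrogen. Within the data shown here, the only measured step bearing on this swapped one chain for a longer chain and stayed within the scatter; a chain giving way to a ring is untested here. No step beyond the scatter is expected in this assay. Compound 3 is estimated at 12%, between 0% and 35%, an expected step of a number 3.7 percentage points higher from compound 2 to compound 3 (within the scatter).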

Compound 3, a percentage reported as activity, at one concentration (the size of the read-out at that concentration, not a potency): 13.5%
Compound 3: middle estimate off by 1.5 percentage points, on the low side, and the stated range covers the measured number.
By their numbers in this assay, from the lowest: compounds 2, 1 and 3 (each within the scatter of the next).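

In this assay, among these compounds, the amide-type nitrogen now carries a ring for the first time: 2-aminophenyl in place of 6-aminohexyl gives a number 5.2 percentage points higher from compound 2 to compound 3 (within the scatter) and 2-aminophenyl in place of 2-aminoethyl gives a number 2 percentage points higher from compound 1 to compound 3 (within the scatter). At this position the six-membered aromatic ring of carbon only is thus not told apart from either chain. Nothing at hand offers a reason for this. As far as these compounds go, whether plain phenyl or hexyl, without the amine, would read the same remains open. So does the effect of a carboxylic acid in the amine's place.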